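The compounds below may be only part of what the source reports. "The series", "measured", "known", "first", "only" and "open" are said of these compounds alone.

Compound 1 `CCSc1nnc(Cc2ccc(Cl)cc2Oc2ccccc2Cl)[nH]1` in a functional assay on the whole organism (strain NMRI) with Mus musculus as the target, with a stated time of 60 min, at a dose of 5 mg/kg by the intraperitoneal route (a higher number here means a stronger effect of the compound at the dose given, a lower number a weaker effect), gives 134%. Compound 2 `CCSc1nnc(Cc2ccc(Cl)cc2Oc2ccccc2F)[nH]1` in this assay gives 126%; the change fluoro in place of chloro on an aromatic carbon made a number 8 percentage points lower from compound 1 to compound 2 (within the scatter). Compound 3 `CCOc1nnc(Cc2ccc(Cl)cc2Oc2ccccc2Cl)[nH]1` in this assay gives 120%; against compound 1 the core differs by ethoxy in place of ethylsulfanyl on an aromatic carbon, which made a number 14 percentage points lower from compound 1 to compound 3 (beyond the scatter). Compound 4 `CCOc1nnc(Cc2ccc(Cl)cc2Oc2ccccc2F)[nH]1` is not yet measured in this assay. From compound 3 to compound 4 the change is fluoro in place of chloro on an aromatic carbon, the same change as from compound 1 to compound 2, at the same place. It is expected that compound 4 stays close to compound 3 because the same change earlier gave a number 8 percentage points lower from compound 1 to compound 2 (within the scatter), a step within the scatter. For compound 4 the expected step is a number 8 percentage points lower from compound 3 to compound 4 (within the scatter). Compound 4 is estimated at 112%, with a range from 98% to 126%.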

Compound 4, a percentage reported as activity, at one dose (the size of the read-out at that dose, not a potency): 111%
Beside the measured number, compound 4's estimate is 1 percentage points above it; measured number inside the range.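

In this assay, fluoro in place of chloro carried over to the second core, with a number 9 percentage points lower from compound 3 to compound 4 (within the scatter), matching the earlier step: the same change on two cores in this assay, a number 8 percentage points lower (within the scatter) from compound 1 to compound 2 and a number 9 percentage points lower (within the scatter) from compound 3 to compound 4, 1 percentage points apart, within the scatter of two such steps. Ethoxy in place of ethylsulfanyl carried over in the same way, with a number 15 percentage points lower from compound 2 to compound 4 (beyond the scatter): the same change on two cores in this assay, a number 14 percentage points lower (beyond the scatter) from compound 1 to compound 3 and a number 15 percentage points lower (beyond the scatter) from compound 2 to compound 4, 1 percentage points apart, within the scatter of two such steps. Across these four compounds at one dose the two changes behave as independent steps, but this does not show that they would do so on any other core or at another dose, and it gives no reason for either step.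

The compounds shown leave open how bromo or methoxy would read in place of the chloro or fluoro. They also leave open whether an amine or a longer chain in place of the ethoxy or ethylsulfanyl would fit this picture.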